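Swapping the aryl hydrazone arm on a shared core

The source may hold more compounds than are shown below. What is called first, only, known or untested is meant among the compounds shown, and "the series" means these compounds.

Compound 1 `CCCSc1nc(N/N=C/c2ccccc2F)c2nnn(Cc3ccccc3)c2n1` reaches only the limit > 64000 nM in a functional assay on MGC-803 cells (Homo sapiens) for antiproliferative activity, read by MTT assay, with a stated time of 72 h; on this read-out lower numbers stand for stronger inhibition and higher numbers for weaker inhibition. Compound 2 `CCCSc1nc(N/N=C/c2cccnc2)c2nnn(Cc3ccccc3)c2n1` gives 38100 nM in this assay.

Among the compounds with values here, compound 2 thus carries the only plain number among the two values shown; the other value is a limit, (the limit of > 64000 nM in this assay, at which 1 of the 2 values shown sits). Within the data shown here, the single measured step, an at least 1.6-fold lower number from compound 1 to compound 2 (0.22 log units; that floor lies within the scatter), is a swap of one ring for another on the carbon that carries the double bond to nitrogen, and its size cannot be told apart from the usual scatter.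

Compound 3 `CCCSc1nc(N/N=C(\C)c2ccc(O)cc2)c2nnn(Cc3ccccc3)c2n1` differs from compound 2 by a group of 10 heavy atoms (8 carbon, 1 nitrogen, 1 oxygen; one six-membered aromatic ring of carbon only) in place of a group of 8 heavy atoms (6 carbon, 2 nitrogen; one six-membered aromatic ring with 1 hetero atom), on a nitrogen on an aromatic ring. No measured step covers this particular change: the one step shown concerns a different pair of rings, and it sits within the scatter. There is therefore no basis to expect a move beyond the scatter in either direction, and compound 3 is expected to land close to compound 2, with an estimated step of a 1.1-fold lower number from compound 2 to compound 3 (0.04 log units; within the scatter). The estimate for compound 3 in this assay is 35000 nM, with a range from 9000 nM to 130000 nM.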

Compound 3, half-maximal inhibitory concentration: 16700 nM
The estimate for compound 3 lay 2.1-fold (0.32 log units) above the measured number; low and high end bracket the measured number.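

At this position, on a nitrogen on an aromatic ring, the compounds now show a change that clears the scatter in this assay: the group of 10 heavy atoms gives a 2.3-fold lower number from compound 2 to compound 3 (0.36 log units; beyond the scatter), which the earlier pair did not show. Compound 1 also carries a six-membered aromatic ring of carbon only, within its own group at this position, yet replacing that group gives an at least 3.8-fold lower number from compound 1 to compound 3 (0.58 log units; beyond the scatter), so the ring type alone does not settle the number. Compound 1 stands only at a limit, which makes the size of that step a floor rather than an exact figure: the limit of > 64000 nM in this assay, at which 1 of the 3 values shown sits.

The group in compound 3 differs from the group in compound 2 in more than one feature at once, including its ring and its 1 hydrogen-bond donor, so these compounds cannot show which feature goes with the lower number. From the compounds shown here alone, it also remains open whether an amine or a carboxylic acid on that aromatic ring would lower the number further in this assay or raise it.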